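A few compounds are considered here, and "the series" means these few. Any claim that something is new, unique, unknown or untested is made for them only; others in the source may bear on it.

Measured compounds:
compound 1, `Nc1cc(N)c2nc(-c3ccccc3)c(NCc3ccc(F)cc3)nc2c1`, < 100000 nM
compound 2, `COc1ccc(CNc2nc3cc(N)cc(N)c3nc2-c2ccccc2)cc1`, 26900 nM

In a functional assay on IGROV-1 cells (Homo sapiens) for inhibition, read by sulforhodamine B assay, with a stated time of 48 h (a lower number here means a stronger inhibitor of growth, a higher number a weaker inhibitor of growth), compound 1 gives only a limit of the assay, < 100000 nM. In this assay compound 2 gives 26900 nM. The change between them, methoxy in place of fluoro on an aromatic carbon, is a step that the limit leaves unreadable from compound 1 to compound 2 because compound 1 sits at the limit of < 100000 nM in this assay, at which 1 of the 2 values shown sits. Compound 1 therefore stands nowhere firm on the numbers shown.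

Compound 3 (`Nc1cc(N)c2nc(-c3ccccc3)c(Oc3ccc(F)cc3)nc2c1`) differs from compound 1 by 4-fluorophenoxy in place of (4-fluorobenzyl)amino on an aromatic carbon. Within the data shown here, no measured step touches this change, and the one measured step is unreadable, so no size or direction beyond the scatter can be drawn from it. Among the measured compounds shown here, the only firm number in the shared core is that of compound 2. On that basis compound 3 is expected to give about 35000 nM in this assay, with a range from 8000 nM to 100000 nM. The step this estimate implies is a step that the limit leaves unreadable from compound 1 to compound 3.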

Compound 3, concentration for total growth inhibition: < 100000 nM
Compound 3: no number, only a limit; the forecaster's own chance of this, stated with the estimate: 35%; the middle value is on the limit's open side.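

In this assay compound 3 gives only a limit, < 100000 nM, so no step can be read between compound 1 and compound 3, which share that limit: the limit of < 100000 nM in this assay, at which 2 of the 3 values shown sit.

The compounds shown leave open whether 4-fluorophenoxy and (4-fluorobenzyl)amino differ at all in their effect on growth inhibition.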